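The source may hold more compounds than are shown below. What is called first, only, known or untested is meant among the compounds shown, and "the series" means these compounds.

Compound 1 `Cc1ccc(NC(=O)Nc2cc(C)nc3ccccc23)cc1` gives > 25000 nM in an ADME assay on HepG2 cells (Homo sapiens) for cytotoxicity, with a stated time of 72 h (a lower number here means that less compound is needed, a higher number that more compound is needed for the effect), which is a limit of the assay and not a number. Compound 2 `Cc1cc(NC(=O)Nc2cccc(C(F)(F)F)c2)c2ccccc2n1` gives 21000 nM in this assay. Compound 3 `Cc1cc(NC(=O)Nc2cccc(C(C)(C)C)c2)c2ccccc2n1` gives > 25000 nM in this assay, again a limit rather than a number. Compound 3 therefore stands at the edge of what this assay reports, where (the limit of > 25000 nM in this assay, at which 2 of the 3 values shown sit). Compound 4 `Cc1cc(NC(=O)Nc2cccc(F)c2)c2ccccc2n1` carries fluoro in place of tert-butyl on an aromatic carbon. Among the measured compounds shown here, the one measured step at this place, an at least 1.1-fold higher number from compound 2 to compound 3 (0.07 log units; that floor lies within the scatter), runs from a number to a limit and stays within the scatter. For compound 4 no step beyond the scatter is therefore expected, and the expected step is a number no higher from compound 3 to compound 4 (the limit leaves the size open). Compound 4 is expected to give about 25000 nM in this assay, between 12000 nM and 50000 nM, most likely reported as a limit once more.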

Compound 4, half-maximal effective concentration: > 25000 nM
Compound 4: no number, only a limit; the forecaster's own chance of this, stated with the estimate: 70%; the middle value sits exactly at the limit.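

Fluoro on this aromatic carbon, like tert-butyl, gives no number, so only trifluoromethyl among the three groups here yields a measured value. Even so, an at least 1.1-fold higher number from compound 2 to compound 4 (0.07 log units; that floor lies within the scatter), so fluoro and trifluoromethyl cannot be told apart at this place; the steps to compound 4 from compound 1 and from compound 3 cannot be read, as both ends of each are limits. Most of the series now rests at one edge of this assay: the limit of > 25000 nM in this assay, at which 3 of the 4 values shown sit.

On these data alone, how far compound 1, compound 3 and compound 4 lie past that limit remains open. Also open, as far as these compounds go, is whether an amine or a carboxylic acid on this aromatic carbon would give a number.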